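This account rests on a few compounds, and the source may have more. Where it says the series, first, only, none or still open, it means among the compounds named here.

Measured so far, in an assay on isolated protein for inhibition of eIF-2-alpha kinase GCN2 (Homo sapiens); on this read-out higher numbers stand for weaker inhibition and lower numbers for stronger inhibition:
compound 2 `Brc1nn(-c2ccc3ncccc3c2)c2nc(N[C@@H]3CC[C@@H](c4ncc[nH]4)C3)ncc12` — 21 nM
compound 1 `COCCC(=O)N[C@@H]1CC[C@@H](Nc2ncc3c(Br)nn(-c4ccc5ncccc5c4)c3n2)C1` — 74 nM

Compound 2 has the lower of the two numbers, with compound 1 standing a step away of a 3.5-fold lower number from compound 1 to compound 2 (0.55 log units; beyond the scatter). Compound 3 `CNC(=O)[C@]1(C)CC[C@@H](Nc2ncc3c(Br)nn(-c4ccc5ncccc5c4)c3n2)C1` differs from compound 2 by a group of 10 heavy atoms (8 carbon, 1 nitrogen, 1 oxygen; one five-membered non-aromatic ring of carbon only) in place of a group of 10 heavy atoms (8 carbon, 2 nitrogen; one five-membered non-aromatic ring of carbon only, one five-membered aromatic ring with 2 hetero atoms), on a nitrogen on an aromatic ring. Within the data shown here, the one measured step shows that the amide-bearing compound 1 gave a higher number than the imidazole-bearing compound 2; compound 3 returns to an amide, though built differently, so a move back toward compound 1 is expected, of about a 2.4-fold higher number from compound 2 to compound 3 (0.38 log units; beyond the scatter). Compound 3 is therefore estimated at 50 nM, with a range from 15 nM to 160 nM.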

Compound 3, half-maximal inhibitory concentration: 17 nM
For compound 3 the middle estimate is 2.9-fold (0.47 log units) above the measured one; the measured number falls inside the stated range.
By their numbers in this assay, from the lowest: compounds 3 and 2 (each within the scatter of the next); then compound 1.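

In this assay the exchange gives a 1.2-fold lower number from compound 2 to compound 3 (0.09 log units; within the scatter), so the two compounds cannot be told apart on this read-out. The group carrying the five-membered aromatic ring with 2 hetero atoms can thus be replaced at this nitrogen by a group with no aromatic ring, and the number stays within the scatter. No measurement at hand explains why these two groups read alike. The compounds shown leave open whether the methyl on the saturated ring carbon or the amide hydrogen matters here. They also leave open how a carboxylic acid or a primary amine would read on that carbon.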